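This account rests on a few compounds, and the source may have more. Where it says the series, first, only, none or still open, it means among the compounds named here.

Compound 1 `O=C(O)c1cnc2cc(F)ccc2c1O` is the weakest of the three compounds measured in an assay on isolated protein with malate dehydrogenase, cytoplasmic (Sus scrofa) as the target (on this read-out higher numbers stand for weaker inhibition and lower numbers for stronger inhibition), where compound 1 gives 11000000 nM, the highest of the three numbers. Compound 2 `O=C(O)c1cnc2cc(O)ccc2c1O` gives 955000 nM, and compound 3 `O=C(O)c1ccc2c(O)c(C(=O)O)cnc2c1` gives 1290000 nM; between these two there is only a 1.4-fold higher number from compound 2 to compound 3 (0.13 log units; within the scatter). Compound 4 `NC(=O)c1ccc2c(O)c(C(=O)O)cnc2c1` differs from compound 1 by carbamoyl in place of fluoro on an aromatic carbon. Among the compounds with values here, the steps that bear on this exchange are a 12-fold lower number from compound 1 to compound 2 (1.06 log units; beyond the scatter) and an 8.5-fold lower number from compound 1 to compound 3 (0.93 log units; beyond the scatter); each replaced the same fluoro and each lowered the number well beyond the scatter. Compound 4 is therefore expected to show a 9.2-fold lower number from compound 1 to compound 4 (0.96 log units; beyond the scatter), a drop of similar size. The estimate for compound 4 in this assay is 1200000 nM, with a range from 400000 nM to 4000000 nM.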

Compound 4, half-maximal inhibitory concentration: 603000 nM
The estimate for compound 4 lay 2.0-fold (0.30 log units) above the measured number; the range from low to high includes it.
By their numbers in this assay, from the lowest: compounds 4, 2 and 3 (each within the scatter of the next, the first and the last beyond it); then compound 1.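

In this assay, carbamoyl is a third group that lowers the number when it replaces fluoro at this position (an 18-fold lower number from compound 1 to compound 4 (1.26 log units; beyond the scatter)), and unlike hydroxy and carboxy it brings a hydrogen-bond donor and acceptor while remaining uncharged in the computed comparison. Swapping hydroxy for amino on the carbonyl carbon gives a modest further gain (a 2.1-fold lower number from compound 3 to compound 4 (0.33 log units; beyond the scatter)), whereas carbamoyl and the hydroxy of compound 2 cannot be told apart (a 1.6-fold lower number from compound 2 to compound 4 (0.20 log units; within the scatter)). Nothing available explains these differences. As far as these compounds go, whether an amine or a methyl group at this position would also lower the number stays open.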